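Swapping Chlorines for Methoxy Groups on a Benzylamine Arm

The source may report more compounds than this note shows. Statements on the series, on what has been measured and on what is new or still open speak of the compounds shown alone.

Of the compounds shown here, three on a shared core have been measured in a functional assay on SK-MEL-28 cells (Homo sapiens) for inhibition, read by sulforhodamine B assay, with a stated time of 48 h; on this read-out higher numbers stand for weaker inhibition of growth and lower numbers for stronger inhibition of growth. Compound 1, `Nc1cc(N)c2nc(-c3ccccc3)c(NCc3ccc(Cl)c(Cl)c3)nc2c1`, gives 41700 nM in this assay. Compound 2, `Nc1cc(N)c2nc(-c3ccccc3)c(Sc3ccc(F)cc3)nc2c1`, gives 53700 nM, and compound 3, `CCOC(=O)[C@H](CCC(=O)O)NC(=O)c1ccc(Oc2nc3cc(N)cc(N)c3nc2-c2ccccc2)cc1`, gives 30200 nM. Compound 1 stands second highest of the three numbers, but its gap to compound 2 and its gap to compound 3 both lie within the usual scatter of repeated measurements, so the three compounds cannot be placed in any order of strength on these data; all three sit at the weak end of the read-out.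

The unmeasured compound 4, `COc1ccc(CNc2nc3cc(N)cc(N)c3nc2-c2ccccc2)cc1OC`, keeps the core and the saturated chain carbon bound to a nitrogen on an aromatic ring, and differs from compound 1 in one place: 3,4-dimethoxyphenyl in place of 3,4-dichlorophenyl on a saturated chain carbon bound to a nitrogen on an aromatic ring. Within the data shown here, no step between measured compounds that differ in one place exists to guide the size of this change, and the three measured compounds already span less than the scatter. The step of a 1.0-fold lower number from compound 1 to compound 4 (0.02 log units; within the scatter) is therefore expected to be small, in no clear direction, and probably not beyond the scatter. Compound 4 is estimated at 40000 nM in this assay, with a range from 15000 nM to 100000 nM.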

Compound 4, concentration for total growth inhibition: 30200 nM
Beside the measured number, compound 4's estimate is 1.3-fold (0.12 log units) above it; measured number inside the range.
By their numbers in this assay, from the lowest: compounds 3, 4, 1 and 2 (each within the scatter of the next).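

In this assay, among these compounds, the swap gives the first reading of a single change at this position, on a saturated chain carbon bound to a nitrogen on an aromatic ring: a 1.4-fold lower number from compound 1 to compound 4 (0.14 log units; within the scatter). The two compounds therefore cannot be told apart, even though 3,4-dimethoxyphenyl carries 2 hydrogen-bond acceptors where 3,4-dichlorophenyl carries 0, so this pair gives no sign that the read-out responds to this exchange of groups on the arm. No accompanying measurement bears on this result, and the reading stands without any explanation.

The compounds shown leave open whether any group at this place can move the number beyond the scatter, for instance an unsubstituted phenyl, a carboxylic acid or an amine in place of 3,4-dimethoxyphenyl. They also leave open whether a longer chain in place of the saturated chain carbon would separate such a compound from compound 1, as this single pair says nothing about the length of the arm.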